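This account rests on a few compounds, and the source may have more. Where it says the series, first, only, none or still open, it means among the compounds named here.

Compound 1 `O=C(/C=C/c1ccc(OCc2cn(Cc3ccccc3F)nn2)cc1)c1ccc(Br)cc1` gives 38% in a functional assay on A549 cells (Homo sapiens) for inhibition, read by MTT assay, with a stated time of 48 h, tested at 10 uM; on this read-out lower numbers stand for less inhibition of growth and higher numbers for more inhibition of growth at the one concentration tested. Compound 2 `O=C(/C=C/c1ccc(OCc2cn(Cc3cccc(F)c3)nn2)cc1)c1ccc(Br)cc1` carries the change 3-fluorophenyl in place of 2-fluorophenyl on a saturated chain carbon bound to an aromatic nitrogen and gives 37% in this assay, so that the step of a number 1 percentage points lower from compound 1 to compound 2 (within the scatter) is small. Compound 3 `COc1ccc(C(=O)/C=C/c2ccc(OCc3cn(Cc4ccccc4F)nn3)cc2)cc1` differs from compound 1 by methoxy in place of bromo on an aromatic carbon; in this assay compound 3 gives 21%, and the step of a number 17 percentage points lower from compound 1 to compound 3 (beyond the scatter) is the only clear one in the set, so that compound 3 sits lowest of the three measured numbers.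

Compound 4 `COc1ccc(C(=O)/C=C/c2ccc(OCc3cn(Cc4cccc(F)c4)nn3)cc2)cc1` is not yet measured. It differs from compound 3 by 3-fluorophenyl in place of 2-fluorophenyl on a saturated chain carbon bound to an aromatic nitrogen, the same change as that from compound 1 to compound 2; the two cores differ by methoxy in place of bromo on an aromatic carbon. Because a number 1 percentage points lower from compound 1 to compound 2 (within the scatter) was within the scatter, the step of a number 1 percentage points lower from compound 3 to compound 4 (within the scatter) is expected to be similarly small. Compound 4 is therefore expected to give about 20% in this assay, between 10% and 30%.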

Compound 4, percent growth inhibition at one concentration: 56%
Compound 4: middle estimate off by 36 percentage points, on the low side, outside the stated range (above it).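

With a number 35 percentage points higher from compound 3 to compound 4 (beyond the scatter), the change from 2-fluorobenzyl to 3-fluorobenzyl in this assay does not carry over in size from the core of compound 1 to the core of compound 3: the same change on two cores in this assay, a number 1 percentage points lower (within the scatter) from compound 1 to compound 2 and a number 35 percentage points higher (beyond the scatter) from compound 3 to compound 4, 36 percentage points apart, beyond the scatter of two such steps

Methoxy in place of bromo also does not carry over, as its direction reverses between the 2-fluorophenyl and 3-fluorophenyl compounds, with a number 19 percentage points higher from compound 2 to compound 4 (beyond the scatter): the same change on two cores in this assay, a number 17 percentage points lower (beyond the scatter) from compound 1 to compound 3 and a number 19 percentage points higher (beyond the scatter) from compound 2 to compound 4, 36 percentage points apart, beyond the scatter of two such steps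

The two changes thus do not add up across these four compounds, but this single set gives no cause for the reversal and no rule for other cores.

Still open, going by these compounds, is whether the rise on the methoxy-bearing core persists with a plain benzyl group or with a nitrile in place of the fluorine. Also open, on these data alone, is how an amine in place of the methoxy would behave with either fluorobenzyl group.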